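The compounds below may be only part of what the source reports. "The series", "measured", "known", "first", "only" and "open" are said of these compounds alone.

Measured in an ADME assay on microsomes from liver (Rattus norvegicus) for metabolic stability, read by LC-MS, using NADPH, with stated times of 10 min and 60 min; a higher number here means faster removal of the compound, a lower number slower removal:
- compound 1 `Cc1nc(CN(C)[C@H]2CCCc3cccnc32)cc(N2CCN(C)[C@@H](C)C2)n1`: 1550 mL/min/kg
- compound 2 `Cc1nc(CN(C)[C@H]2CCCc3cccnc32)cc(N2CCN(C)[C@H](C)C2)n1`: > 497 mL/min/kg

Compound 2 gives > 497 mL/min/kg, which is a limit of the assay and not a number. Within the data shown here, the only measured comparison is a step that the limit leaves unreadable from compound 1 to compound 2, so it offers no size to carry forward. Compound 3 `Cc1nc(CN(C)[C@H]2CCCc3cccnc32)cc(N2CCN3CCC[C@H]3C2)n1` differs from compound 2 by one change: a group of 9 heavy atoms (7 carbon, 2 nitrogen; one five-membered non-aromatic ring with 1 hetero atom, one six-membered non-aromatic ring with 2 hetero atoms) in place of a group of 8 heavy atoms (6 carbon, 2 nitrogen; one six-membered non-aromatic ring with 2 hetero atoms), on an aromatic carbon. Among the measured compounds shown here, no measured step involves this kind of change, so no shift beyond the scatter can be predicted in this assay, in either direction. The expected size is a step that the limit leaves unreadable from compound 2 to compound 3. Compound 3 is estimated at 600 mL/min/kg, with an expected range of 250 mL/min/kg to 1500 mL/min/kg.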

Compound 3, clearance: > 497 mL/min/kg
Compound 3: a limit, no number; the forecaster's own chance of this, stated with the estimate: 50%; the middle value lies beyond the limit too.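

Among these compounds, compound 2 and compound 3 each give only a limit, so no step among compound 1, compound 2 and compound 3 can be read: the limit of > 497 mL/min/kg in this assay, at which 2 of the 3 values shown sit. From the compounds shown here alone, how fast compound 2 and compound 3 are actually removed stays open, and so does whether the change of group between them alters that removal.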